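Furan-3-yl in place of 4-methoxyphenyl: working notes

The source may hold more compounds than are shown below. What is called first, only, known or untested is meant among the compounds shown, and "the series" means these compounds.

Measured in a functional assay on CAPAN-1 cells (Homo sapiens) for antiproliferative activity, with a stated time of 72 h; a lower number here means a stronger inhibitor, a higher number a weaker inhibitor:
- compound 1 `Nc1ncnn2c([C@@H]3O[C@H](CO)[C@@H](O)[C@H]3O)cc(C#Cc3cccs3)c12`: 32000 nM
- compound 2 `COc1ccc(-c2cc([C@@H]3O[C@H](CO)[C@@H](O)[C@H]3O)n3ncnc(N)c23)cc1`: 43900 nM

Not yet measured: compound 3 `Nc1ncnn2c([C@@H]3O[C@H](CO)[C@@H](O)[C@H]3O)cc(-c3ccoc3)c12`.

Compound 2 gives 43900 nM, which lies within the scatter of compound 1, so the two cannot be ranked. Both sit in the same weak range, and compound 2 is the starting point for the next step.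

Compound 3 carries furan-3-yl in place of 4-methoxyphenyl on an aromatic carbon. The site is on a five-membered aromatic ring with 1 nitrogen, two ring bonds from the ring nitrogen.

Within the data shown here, only one measured step bears on this change: a 1.4-fold higher number from compound 1 to compound 2 (0.14 log units; within the scatter). It exchanges one group at the same site for another and stays within the scatter. It gives no reason to expect a large shift, but neither measured compound carries a group as small as furan-3-yl, so the data leave the size of the step open. A modest move to a lower number is expected, with wide uncertainty. The estimated step is a 4.4-fold lower number from compound 2 to compound 3 (0.64 log units; beyond the scatter). For compound 3 the expected value is 10000 nM, with an estimated range of 1000 nM to 50000 nM.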

Compound 3, half-maximal inhibitory concentration: 900 nM
Compound 3: the middle estimate sits 11-fold (1.05 log units) above what was measured; the whole stated range lies above it.
By their numbers in this assay, from the lowest: compound 3; then compounds 1 and 2 (each within the scatter of the next).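

In this assay, the aromatic carbon two ring bonds from the ring nitrogen proves able to move the read-out strongly: furan-3-yl in place of 4-methoxyphenyl gives a 49-fold lower number from compound 2 to compound 3 (1.69 log units; beyond the scatter) and furan-3-yl in place of 2-(thiophen-2-yl)ethynyl gives a 36-fold lower number from compound 1 to compound 3 (1.55 log units; beyond the scatter) at the same site. The first two compounds lie within the scatter of each other and gave no sign of this sensitivity, whereas compound 3 stands clearly apart from both, with furan-3-yl bringing 5 heavy atoms against the 8 of 4-methoxyphenyl and the same hydrogen-bond donor and acceptor counts. No measurement shown accounts for this large step.

Each step replaces a whole group, so the compounds shown cannot separate the contribution of ring size, of the furan oxygen and of the overall size of the group. Furan-2-yl, thiophen-3-yl, unsubstituted phenyl or a small amine on this aromatic carbon would be needed to show which of these features tracks with the lower number.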